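Capping a hydroxy of compound 2

This account rests on a few compounds, and the source may have more. Where it says the series, first, only, none or still open, it means among the compounds named here.

Three compounds share the core of compound 1 `O=C1NC(=O)c2c1c1c(O)cccc1c1[nH]c3ccccc3c21`. In a functional assay on HCT-116 cells (Homo sapiens) for antiproliferative activity, with a stated time of 4 h (on this read-out lower numbers stand for stronger inhibition and higher numbers for weaker inhibition), compound 1 gives 17500 nM. Compound 2 `O=C1NC(=O)c2c1c1c(O)ccc(O)c1c1[nH]c3ccccc3c21` gives 3100 nM, and compound 3 `Cc1ccc2[nH]c3c4c(O)ccc(O)c4c4c(c3c2c1)C(=O)NC4=O` gives 1600 nM. Compound 2 therefore sits well under compound 1 and cannot be separated from compound 3.

Compound 4 `CC(C)(C)C(=O)Oc1ccc(O)c2c3c(c4c5ccccc5[nH]c4c12)C(=O)NC3=O` has not been measured. It differs from compound 2 by (tert-butyl)carbonyl in place of hydrogen on an oxygen on an aromatic ring, or hydroxy to ((tert-butyl)carbonyl)oxy.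

Neither measured step is this same change. The more relevant is a 5.6-fold lower number from compound 1 to compound 2 (0.75 log units; beyond the scatter), where hydroxy replaces hydrogen on an aromatic carbon, since the new change falls on a hydroxy. If that hydroxy matters, part of this step may be given back, which points towards a higher number. The other step, a 1.9-fold lower number from compound 2 to compound 3 (0.29 log units; within the scatter), places methyl on an aromatic carbon and says little here. Going by the values given here, no measured compound carries (tert-butyl)carbonyl, so the size remains uncertain.

In this assay the expected step is a 2.3-fold higher number from compound 2 to compound 4 (0.35 log units; beyond the scatter), a modest move towards weaker inhibition. The estimate for compound 4 is 7000 nM, with an expected range from 2000 nM to 22000 nM.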

Compound 4, half-maximal inhibitory concentration: 8760 nM
The estimate for compound 4 lay 1.3-fold (0.10 log units) below the measured number, within the range that was stated.
By their numbers in this assay, from the lowest: compounds 3 and 2 (each within the scatter of the next); then compounds 4 and 1 (each within the scatter of the next).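

In this assay, capping the hydroxy as ((tert-butyl)carbonyl)oxy produces a 2.8-fold higher number from compound 2 to compound 4 (0.45 log units; beyond the scatter) and lies beyond the scatter, the first sign in the series that this oxygen does not tolerate every substituent. Set against the compound without the group, the same ((tert-butyl)carbonyl)oxy gives a 2.0-fold lower number from compound 1 to compound 4 (0.30 log units; within the scatter) and stays within the scatter, so compound 4 cannot be separated from compound 1. The gain seen in a 5.6-fold lower number from compound 1 to compound 2 (0.75 log units; beyond the scatter) therefore appears with the free hydroxy and does not survive with this ester in its place, although compound 4 does not fall measurably behind compound 1.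

On these data alone, whether the loss follows from capping the oxygen as such or from the tert-butyl in particular stays open, and a methyl ether or an acetyl ester at this oxygen would separate the two readings. Also open, as far as these compounds go, is whether the same ester on the other hydroxy, or on the methyl-bearing compound 3, would behave in the same way. Nothing available explains why the ester behaves as it does.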